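Positional isomer of the trifluoromethylphenyl hydrazone in the series

This account rests on a few compounds, and the source may have more. Where it says the series, first, only, none or still open, it means among the compounds named here.

Measured so far:
compound 1 `Cc1nc(N(C)C(=O)NC(=O)c2c(F)cccc2F)sc1C(=O)N/N=C/c1ccccc1C(F)(F)F` — 7.88 ug/mL
compound 2 `CN(C(=O)NC(=O)c1c(F)cccc1F)c1nc(C(F)(F)F)c(C(=O)N/N=C/c2ccccc2C(F)(F)F)s1` — 17 ug/mL

In a functional assay on BCG823 cells (Homo sapiens) for inhibition, read by MTT assay, with a stated time of 72 h (a lower number here means a stronger inhibitor, a higher number a weaker inhibitor), compound 1 gives 7.88 ug/mL, the lowest number of the two measured; the nearest is compound 2, which shows a 2.2-fold higher number from compound 1 to compound 2 (0.33 log units; beyond the scatter) and in which the change is trifluoromethyl in place of methyl on an aromatic carbon of the shared core.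

Compound 3 `Cc1nc(N(C)C(=O)NC(=O)c2c(F)cccc2F)sc1C(=O)N/N=C/c1ccc(C(F)(F)F)cc1` differs from compound 1 in another part of the molecule: 4-(trifluoromethyl)phenyl in place of 2-(trifluoromethyl)phenyl on a carbon with a double bond to nitrogen. Going by the values given here, no measured step touches this carbon with a double bond to nitrogen; the single step from compound 1 to compound 2 concerns the core and offers no guidance here. Without a bearing step, no move beyond the scatter is expected in this assay, so the expected step is a 1.0-fold higher number from compound 1 to compound 3 (0.01 log units; within the scatter). Compound 3 is estimated at 8 ug/mL, with a range from 3 ug/mL to 20 ug/mL.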

Compound 3, half-maximal inhibitory concentration: 65.5 ug/mL
The estimate for compound 3 lay 8.2-fold (0.91 log units) below the measured number; measured number outside the range, above it.
By their numbers in this assay, from the lowest: compound 1; then compound 2; then compound 3.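

In this assay, the group on the carbon with a double bond to nitrogen proves sensitive to the placement of the trifluoromethyl: 4-(trifluoromethyl)phenyl in place of 2-(trifluoromethyl)phenyl gives an 8.3-fold higher number from compound 1 to compound 3 (0.92 log units; beyond the scatter), with the atoms of the group unchanged. This step is larger than the core change, a 2.2-fold higher number from compound 1 to compound 2 (0.33 log units; beyond the scatter), so of the two places varied so far, this one moves the number further. No available data explain the difference between the two arrangements.

Open, on these data alone, is how a plain phenyl, or a chlorine atom or methoxy group in place of the trifluoromethyl, would read at this carbon. Also open, as far as these compounds go, is whether 4-(trifluoromethyl)phenyl would raise the number to a similar extent on the core of compound 2.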